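A few compounds are considered here, and "the series" means these few. Any claim that something is new, unique, unknown or untested is made for them only; others in the source may bear on it.

Measured compounds in an ADME assay on HepG2 cells (Homo sapiens) for cytotoxicity, with a stated time of 3 days; a higher number here means that more compound is tolerated, a lower number that less compound is tolerated:
compound 1, `CC(Sc1nnc(-c2ccncc2)s1)C(=O)NCc1ccc(Cl)cc1`: "not determined" (no result reported)
compound 2, `O=C(CSc1nnc(-c2ccncc2)s1)Nc1c(Cl)cccc1Cl`: "not determined" (no result reported)
compound 3, `O=C(CSc1nnc(-c2ccncc2)s1)NCc1ccc(Cl)cc1`: > 50000 nM

For the measured compounds named here, for compound 3 this assay reports only a limit, > 50000 nM, not a number; compound 3 thus sits at the limit of > 50000 nM in this assay, at which 1 of the 3 values shown sits, and the other two entries carry no number at all, so no measured step exists.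

Compound 4, `O=C(CSc1nnc(-c2ccncc2)s1)NCc1ccccc1`, differs from compound 3 by hydrogen in place of chloro on an aromatic carbon. With compound 3 already at the limit in this assay, the step from compound 3 to compound 4 is expected to be none beyond the scatter, a step that the limit leaves unreadable from compound 3 to compound 4, most likely again ending at the limit.

Compound 4 is therefore estimated at 60000 nM, with a range of 25000 nM to 150000 nM.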

Compound 4, half-maximal cytotoxic concentration: 17700 nM
For compound 4 the middle estimate is 3.4-fold (0.53 log units) above the measured one, outside the stated range (below it).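

In this assay, for the compounds shown here, the change from 4-chlorobenzyl to benzyl gives the first readable step, an at least 2.8-fold lower number from compound 3 to compound 4 (0.45 log units; beyond the scatter). Removing the chloro from this aromatic carbon therefore registers in the read-out, which the earlier entries could not show. Compound 3 holds a limit and not a number, so the step gives only a minimum size: the limit of > 50000 nM in this assay, at which 1 of the 4 values shown sits.

From the compounds shown here alone, whether a fluoro or a methoxy group at this place would read like chloro or like hydrogen stays open. Compound 1 and compound 2 carry no number, so steps to them cannot be read.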